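Oxime ether series: ester to acid at the ether terminus

The source may hold more compounds than are shown below. What is called first, only, known or untested is meant among the compounds shown, and "the series" means these compounds.

For the measured compounds named here, compound 2 `CCOC(=O)CO/N=C(/c1ccc(OC)c(OC)c1OC)c1cccc2ccccc12` gives 3360 nM in a functional assay on HCT-116 cells (Homo sapiens) for inhibition, read by sulforhodamine B assay, with a stated time of 48 h (a higher number here means a weaker inhibitor, a lower number a stronger inhibitor), the lowest of the two numbers so far; compound 1 `COc1ccc(/C(=N/O)c2cccc3ccccc23)c(OC)c1OC` gives 5880 nM, and the step of a 1.8-fold lower number from compound 1 to compound 2 (0.24 log units; within the scatter) lies within the scatter. Compound 3 `COc1ccc(/C(=N/OCC(=O)O)c2cccc3ccccc23)c(OC)c1OC` differs from compound 2 by hydrogen in place of ethyl on an oxygen next to a carbonyl group. Going by the values given here, no measured step covers this change; the only step known concerns the other end of the same chain and was itself within the scatter. Compound 3 is therefore expected to stay near compound 2, with a 1.3-fold higher number from compound 2 to compound 3 (0.13 log units; within the scatter) in this assay, giving an estimate of 4500 nM, ranging from 1500 nM to 15000 nM.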

Compound 3, half-maximal inhibitory concentration: 4980 nM
The estimate for compound 3 lay 1.1-fold (0.04 log units) below the measured number; the range from low to high includes it.
By their numbers in this assay, from the lowest: compounds 2, 3 and 1 (each within the scatter of the next).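

Hydrogen in place of ethyl on an oxygen next to a carbonyl group gives a 1.5-fold higher number from compound 2 to compound 3 (0.17 log units; within the scatter) in this assay, so ethoxycarbonyl to carboxy at the chain end does not separate these two compounds. Carboxymethyl in place of hydrogen on an oxygen gives a 1.2-fold lower number from compound 1 to compound 3 (0.07 log units; within the scatter), so this chain, like (ethoxycarbonyl)methyl, stays within the scatter of the parent compound 1. No available evidence bears on this result. As far as these compounds go, whether a primary amide or an amine at the chain end, or a longer chain, would give a step beyond the scatter remains open.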